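This account rests on a few compounds, and the source may have more. Where it says the series, first, only, none or still open, it means among the compounds named here.

Working notes on the urea series

Three members have numbers in a functional assay on HCC827 cells (Homo sapiens) for inhibition, read by MTT assay, with a stated time of 48 h, tested at 10 uM (a higher number here means more inhibition at the concentration tested (going by the name of the read-out), a lower number less inhibition), so far. Compound 1 `COc1ccc(F)cc1Nc1cc(NC(=O)Nc2c(Cl)cccc2Cl)ncn1` is the highest of the three, giving 78% in this assay. Compound 3 `COc1cc(Nc2cc(NC(=O)Nc3c(Cl)cccc3Cl)ncn2)cc(OC)c1` also sits high, giving 73.7% in this assay. Compound 2 `CCc1cccc(Nc2cc(NC(=O)Nc3cc(OC)cc(OC)c3)ncn2)c1` is the lowest of the three: in this assay compound 2 gives 52.6%, and the gap to compound 3, its nearest neighbour on the numbers, as well as the larger gap to compound 1, both lie beyond the usual scatter of repeated measurements.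

The next compound to be measured is compound 4 `COc1cc(NC(=O)Nc2cc(Nc3ccc(Br)cc3OC)ncn2)cc(OC)c1`. Relative to compound 2 it carries one change: 4-bromo-2-methoxyphenyl in place of 3-ethylphenyl on a nitrogen on an aromatic ring. Among the compounds with values here, no pair of measured compounds differs in exactly this way, so no measured step directly mirrors it. Within the data shown here, compound 4 nevertheless shares its remaining part with compound 3, which already reaches 73.7% in this assay, and the aryl group it gains resembles the one found in compound 1.

On that basis a rise of a size well beyond the scatter is expected from compound 2 to compound 4, namely a number 17.4 percentage points higher from compound 2 to compound 4 (beyond the scatter). Compound 4 is thus estimated to give about 70% in this assay, most likely between 50% and 88%.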

Compound 4, a percentage reported as inhibition, at one concentration (the size of the read-out at that concentration, not a potency): 57.7%
For compound 4 the middle estimate is 12.3 percentage points above the measured one, and the stated range covers the measured number.
By their numbers in this assay, from the lowest: compounds 2 and 4 (each within the scatter of the next); then compounds 3 and 1 (each within the scatter of the next).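

Within the data shown here, this is the first measured step at this position: in this assay, 4-bromo-2-methoxyphenyl in place of 3-ethylphenyl on a nitrogen on an aromatic ring gives a number 5.1 percentage points higher from compound 2 to compound 4 (within the scatter). With the rest of the molecule held constant, these two aryl groups are therefore not separated by this read-out, even though the entering group has a methoxy and a bromine and the leaving group has an ethyl. No supporting data bear on why the two compounds read alike.

Among these compounds, the single step does not show which part of the entering group matters, since the methoxy and the bromine change together and neither is seen alone, and a reading at one concentration gives no potency. Also open, on these data alone, are how an unsubstituted phenyl, a dimethylamino group or a carboxylic acid on the aryl ring would read at this position, and whether the same change would give a step of similar size with the urea partner carried by compound 3.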